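Removing the nitrophenyl group: expected cytotoxicity of compound 4

The source may report more compounds than this note shows. Statements on the series, on what has been measured and on what is new or still open speak of the compounds shown alone.

Compound 1, `Cc1ccccc1OCc1cn(-c2ccc(S(=O)(=O)N3CCc4ccccc4C3)cc2)nn1`: in an ADME assay on Vero cells (Chlorocebus sabaeus) for cytotoxicity, with a stated time of 4 days (a higher number here means a weaker inhibitor, a lower number a stronger inhibitor), compound 1 gives > 50 ug/mL, a limit of the assay.
Compound 2, `Cc1ccc(OCc2cn(-c3ccc(S(=O)(=O)N4CCc5ccccc5C4)cc3)nn2)cc1`: in this assay compound 2 gives > 50 ug/mL, again a limit.
Compound 3, `COc1cc2c(cc1OC)CN(S(=O)(=O)c1ccc(-n3cc(COc4ccc([N+](=O)[O-])cc4)nn3)cc1)CC2`: in this assay compound 3 gives > 50 ug/mL, also a limit.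

Compound 3 therefore stands at the same limit as every other measured compound, as the limit of > 50 ug/mL in this assay, at which 3 of the 3 values shown sit, shows. Going by the values given here, the only measured step, a step that the two limits leave unreadable from compound 1 to compound 2, is unreadable because both ends are limits. Compound 4, `COc1cc2c(cc1OC)CN(S(=O)(=O)c1ccc(-n3cc(CO)nn3)cc1)CC2`, arises from compound 3 by hydrogen in place of 4-nitrophenyl on an oxygen on a saturated carbon. Among the compounds with values here, no measured step speaks to this change, and nothing here suggests a readable step in this assay. Compound 4 is expected to remain at the limit, estimated at 50 ug/mL (range 30 ug/mL to 100 ug/mL), a step of a number no higher from compound 3 to compound 4 (the limit leaves the size open).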

Compound 4, half-maximal inhibitory concentration: > 50 ug/mL
Compound 4 gave a limit, no number (the forecaster's own chance of this, stated with the estimate: 80%); the middle value sits exactly at the limit.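

Compound 3 and compound 4 both sit at a limit of this assay, so no step can be read between them: the limit of > 50 ug/mL in this assay, at which 4 of the 4 values shown sit.

The compounds shown leave open whether replacing 4-nitrophenyl with hydrogen changes cytotoxicity at all.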